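Swapping the cyano for a methanesulfonamide on the pyrazole aryl

The source may report more compounds than this note shows. Statements on the series, on what has been measured and on what is new or still open speak of the compounds shown alone.

Three ureas sharing one core have been measured in an assay on isolated protein for inhibition of serine/threonine-protein kinase 10 (Homo sapiens), read by thermal shift assay, tested at 10 uM; on this read-out lower numbers stand for weaker stabilisation of the target and higher numbers for stronger stabilisation of the target against heat. Compound 2 `CC(C)(C)c1cc(NC(=O)Nc2ccc(Cl)cc2)n(-c2ccc(C#N)cc2)n1` gives 2.2 degrees C, the highest of the three numbers, although compound 1 `CC(C)(C)c1cc(NC(=O)Nc2cc(F)cc(F)c2)n(-c2ccc(F)cc2)n1` with 1.7 degrees C lies within the scatter of it. Compound 3 `N#Cc1ccc(-n2nc(C3CC3)cc2NC(=O)Nc2ccc(Cl)cc2)cc1` gives -0.7 degrees C, and the step of a number 2.9 degrees C lower from compound 2 to compound 3 (beyond the scatter) is the only one in this set that clearly exceeds the scatter. Compound 4 `CC(C)(C)c1cc(NC(=O)Nc2ccc(Cl)cc2)n(-c2ccc(NS(C)(=O)=O)cc2)n1` differs from compound 2 in a single place: methanesulfonamido in place of cyano on an aromatic carbon. Within the data shown here, no measured pair shows this exchange, nor any change at that position of the ring; the one step that has been seen concerns the other end of the core, where tert-butyl was replaced by cyclopropyl, and so it bears only indirectly on the present question. Since compound 1, carrying a different group on the same ring, sits close to compound 2, the change is expected to leave the melting-temperature shift roughly where it is, with a number 0.30 degrees C lower from compound 2 to compound 4 (within the scatter) estimated to stay within the scatter. Compound 4 is therefore expected to give about 1.9 degrees C, in a range from 0.2 degrees C to 3.6 degrees C.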

Compound 4, shift of the target's melting temperature: 8.9 degrees C
The estimate for compound 4 lay 7.0 degrees C below the measured number; measured number outside the range, above it.
By their numbers in this assay, from the lowest: compound 3; then compounds 1 and 2 (each within the scatter of the next); then compound 4.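

In this assay, the exchange of cyano for methanesulfonamido on this aromatic carbon comes with a number 6.7 degrees C higher from compound 2 to compound 4 (beyond the scatter) and puts compound 4 above all the others. Among these compounds, this shows that the position is far from indifferent to what it carries, which the earlier compounds could not show, as the only step among them was cyclopropyl in place of tert-butyl. Methanesulfonamido brings a hydrogen-bond donor and more heavy atoms than cyano, but nothing available accounts for the rise in stabilisation.

From the compounds shown here alone, it remains open what an acetamido group, an amine or the longer ethanesulfonamido group would give on this carbon, and so which part of methanesulfonamido matters. Going by these compounds, it is also open whether methanesulfonamido would raise the number similarly with the cyclopropyl group of compound 3 in place of tert-butyl.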